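Fluoro in place of methoxy at compound 3

The source may hold more compounds than are shown below. What is called first, only, known or untested is meant among the compounds shown, and "the series" means these compounds.

Values in an ADME assay on MDBK cells (Bos taurus) for cytotoxicity; a higher number here means that more compound is tolerated, a lower number that less compound is tolerated:
Compound 1 `c1ccc(Cn2ccc3nc(-c4ccccc4)nc-3c2)cc1`: > 100000 nM
Compound 2 `Cc1ccc(Cn2ccc3nc(-c4ccccc4)nc-3c2)cc1`: > 100000 nM
Compound 3 `COc1ccccc1Cn1ccc2nc(-c3ccccc3)nc-2c1`: > 100000 nM

Compound 3 gives > 100000 nM, which is a limit of the assay and not a number. It has no readable place among the three, which all share (the limit of > 100000 nM in this assay, at which 3 of the 3 values shown sit). Compound 4 `Fc1ccccc1Cn1ccc2nc(-c3ccccc3)nc-2c1` carries fluoro in place of methoxy on an aromatic carbon, ortho to a large group: fluoro in place of methoxy on an aromatic carbon. Among the measured compounds shown here, three measured steps bear on this: a step that the two limits leave unreadable from compound 1 to compound 2, a step that the two limits leave unreadable from compound 1 to compound 3 and a step that the two limits leave unreadable from compound 2 to compound 3. None of them has a readable size, so no step beyond the scatter and no direction is expected in this assay. Compound 4 is expected near 100000 nM, with an estimated range of 60000 nM to 200000 nM.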

Compound 4, half-maximal cytotoxic concentration: > 100000 nM
Compound 4 was reported as a limit; the forecaster's own chance of this, stated with the estimate: 85%; the middle value lies on the limit itself.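

No step can be read between compound 1, compound 2, compound 3 and compound 4 in this assay, since all four stand at a limit of the assay and not at a number: the limit of > 100000 nM in this assay, at which 4 of the 4 values shown sit. The compounds shown leave open at what concentration any of them becomes cytotoxic, and whether methyl, methoxy or fluoro changes that concentration.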